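Truncation of the aryl group on the five-membered ring

This account rests on a few compounds, and the source may have more. Where it says the series, first, only, none or still open, it means among the compounds named here.

Measured compounds:
compound 1 `COc1ccc(-c2c(C#N)c(N)nc(SCc3nc(-c4ccc(Cl)cc4)sc3Br)c2C#N)cc1`, 162 nM
compound 2 `COc1ccc(-c2c(C#N)c(N)nc(SCc3csc(-c4ccccc4Cl)n3)c2C#N)cc1`, 11 nM

In an assay on CHO cells for displacement of a labelled ligand from adenosine receptor A1 (Homo sapiens) (a lower number here means a stronger inhibitor, a higher number a weaker inhibitor), compound 2 gives the lowest of the two numbers recorded so far, 11 nM. Its nearest neighbour is compound 1, which in this assay gives 162 nM, a gap well beyond the usual scatter. Among the measured compounds shown here, no pair differing in a single place has been measured, so no step size is known.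

Compound 3 `COc1ccc(-c2c(C#N)c(N)nc(SCc3cscn3)c2C#N)cc1` is not yet measured in this assay. It differs from compound 2 as follows: hydrogen in place of 2-chlorophenyl on an aromatic carbon.

Nothing measured here shows what this truncation does. The expectation is a clear loss: the group removed accounts for a large part of the substituent on the five-membered ring, and compound 2 with that group in place gives 11 nM. Compound 3 is therefore expected to reach only 400 nM (estimated range 80 nM to 2500 nM), which means an expected step of a 36-fold higher number from compound 2 to compound 3 (1.56 log units; beyond the scatter), a weakening beyond the scatter.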

Compound 3, inhibition constant: 1.3 nM
Beside the measured number, compound 3's estimate is 310-fold (2.49 log units) above it; measured number below the stated range.
By their numbers in this assay, from the lowest: compound 3; then compound 2; then compound 1.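

In this assay, replacing the 2-chlorophenyl with hydrogen on the aromatic carbon next to the ring nitrogen and next to the ring sulfur gives an 8.5-fold lower number from compound 2 to compound 3 (0.93 log units; beyond the scatter). The 2-chlorophenyl is therefore not required for strong inhibition in this pair, and compound 3 reaches 1.3 nM with no substituent other than hydrogen at this place. The data on hand give no explanation for why the number falls when this six-membered aromatic ring leaves.

This single step leaves open whether hydrogen is especially favourable at this carbon or whether only the 2-chlorophenyl is disfavoured; a methyl, an amine or a carboxylic acid in the same place would help separate these readings. Going by these compounds, it is also open whether an unsubstituted phenyl would give a number closer to that of compound 2 or compound 3, which would show how much of the step follows the chlorine and how much the ring that carries it.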